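Methoxy in Place of Fluoro at the Aromatic Carbon

The source may report more compounds than this note shows. Statements on the series, on what has been measured and on what is new or still open speak of the compounds shown alone.

Compound 1 `O=C1CSC(c2cccc(O)c2)N1CCN1CCCCC1` and compound 2 `O=C1CSC(c2cccc(F)c2)N1CCN1CCCCC1` share the same core and differ at a single aromatic carbon. In an ADME assay on Vero cells (Chlorocebus sabaeus) for cytotoxicity, read by neutral red uptake, tested at 3150 ug/mL (a lower number here means a stronger effect, a higher number a weaker effect of the compound at the concentration tested), compound 1 gives 11%, and compound 2 gives 13%. The step of a number 2 percentage points higher from compound 1 to compound 2 (within the scatter) shows that this exchange left the reading essentially where it was. Compound 2 gives the higher of the two figures, but the gap to compound 1 lies within the usual scatter, so the two cannot be told apart here.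

Compound 3 `COc1cccc(C2SCC(=O)N2CCN2CCCCC2)c1` has not yet been measured. It differs from compound 2 in one place: methoxy in place of fluoro on an aromatic carbon. Going by the values given here, the only measured step that touches this position is a number 2 percentage points higher from compound 1 to compound 2 (within the scatter), and it was small. Since one substituent again replaces another at the same aromatic carbon, a step of no change at the digits printed from compound 2 to compound 3 (within the scatter) is expected, which is none beyond the scatter. Compound 3 is therefore estimated at 13% in this assay, with a range from 5% to 22%.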

Compound 3, a percentage reported as activity, at one concentration (the size of the read-out at that concentration, not a potency): 6%
For compound 3 the middle estimate is 7 percentage points above the measured one; low and high end bracket the measured number.
By their numbers in this assay, from the lowest: compounds 3, 1 and 2 (each within the scatter of the next).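

In this assay, the exchange of fluoro for methoxy gives a number 7 percentage points lower from compound 2 to compound 3 (within the scatter), and putting methyl in place of the hydrogen on the oxygen of the hydroxy group gives a number 5 percentage points lower from compound 1 to compound 3 (within the scatter). With a third group now measured at this aromatic carbon, hydroxy, fluoro and methoxy cannot be told apart in this read-out, and this also holds for the pair that differs only by that methyl. Nothing available explains why these exchanges leave the reading within the scatter.

As far as these compounds go, whether an amine or a carboxylic acid at this same aromatic carbon would move the reading beyond the scatter remains open. A longer chain on the oxygen, such as ethoxy or propoxy, is equally untested among the compounds shown, and a single concentration says nothing about how the effect would change at other concentrations.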